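A few compounds are considered here, and "the series" means these few. Any claim that something is new, unique, unknown or untested is made for them only; others in the source may bear on it.

In an assay on Sf9 cells for inhibition of activin receptor type-1 (Homo sapiens), read by HTRF, with a stated time of 3 h, in the presence of a further agent that is not named here (a lower number here means a stronger inhibitor, a higher number a weaker inhibitor), the measured compounds are:
compound 1 `COC(=O)N1C[C@@H](C)N(c2ncc3[nH]nc(-c4ccc(N5CCN(C)CC5)cc4)c3n2)[C@@H](C)C1` with 0.98 nM
compound 2 `C[C@@H]1CN(c2ccc(-c3n[nH]c4cnc(N5CCCCC5)nc34)cn2)CCN1` with 40 nM

Compound 1 gives the lowest of the two numbers; compound 2 stands at a higher number, a gap that lies beyond the scatter. Compound 3 `COC(=O)N1C[C@@H](C)N(c2ncc3[nH]nc(-c4ccc(N5CCN(C)CC5)c(F)c4)c3n2)[C@@H](C)C1` has not been measured in this assay. It differs from compound 1 by fluoro in place of hydrogen on an aromatic carbon. For the measured compounds named here, no step between two measured compounds bears on this change, so the expectation rests on compound 1 alone. The step from compound 1 to compound 3 is expected to be small, a 1.2-fold higher number from compound 1 to compound 3 (0.09 log units; within the scatter), not beyond the scatter in either direction. Compound 3 is estimated at 1.2 nM, in the range from 0.4 nM to 4 nM.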

Compound 3, half-maximal inhibitory concentration: 1.3 nM
Compound 3: middle estimate off by 1.1-fold (0.03 log units), on the low side; the range from low to high includes it.
By their numbers in this assay, from the lowest: compounds 1 and 3 (each within the scatter of the next); then compound 2.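

In this assay, fluoro in place of hydrogen on an aromatic carbon, ortho to a 4-methylpiperazin-1-yl group, gives a 1.3-fold higher number from compound 1 to compound 3 (0.12 log units; within the scatter), so this place on the six-membered aromatic ring accepts a fluoro group without a step beyond the scatter. Compounds 1 and 2 differ in more than one place and could not show this. No measurement shown here offers an explanation for this result. As far as these compounds go, whether chloro, methoxy or a nitrile at this place would stay as close to compound 1 remains open. So does the outcome of fluoro on the other carbons of this ring.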